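Halogen swap on the aryl isoxazole arm

The compounds below may be only part of what the source reports. "The series", "measured", "known", "first", "only" and "open" are said of these compounds alone.

Compound 1 `O=[N+]([O-])c1ccc(CN2CCC(n3cc(CC(OCc4cc(-c5ccccc5)no4)c4ccc(Br)cc4)nn3)CC2)cc1` in a functional assay on PC-3 cells (Homo sapiens) for cytotoxicity, with a stated time of 48 h (on this read-out higher numbers stand for weaker inhibition and lower numbers for stronger inhibition), returns only the assay limit > 25000 nM. Compound 2 `O=[N+]([O-])c1ccc(CN2CCC(n3cc(CC(OCc4cc(-c5ccc(Br)cc5)no4)c4ccc(Br)cc4)nn3)CC2)cc1` likewise returns only the limit > 25000 nM in this assay. The step that the two limits leave unreadable from compound 1 to compound 2 is accordingly not readable, with both values sitting at the limit of > 25000 nM in this assay, at which 2 of the 2 values shown sit. Compound 3 `O=[N+]([O-])c1ccc(CN2CCC(n3cc(CC(OCc4cc(-c5ccc(F)cc5)no4)c4ccc(Br)cc4)nn3)CC2)cc1` differs from compound 2 by fluoro in place of bromo on an aromatic carbon. Within the data shown here, no measured step is readable for sizing that change, and no value below the limit anchors it. Compound 3 is therefore expected to remain at the limit, the estimated step being a step that the limit leaves unreadable from compound 2 to compound 3. The estimate for compound 3 is 35000 nM, spanning 10000 nM to 120000 nM.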

Compound 3, half-maximal inhibitory concentration: > 25000 nM
Compound 3 gave a limit, no number; the forecaster's own chance of this, stated with the estimate: 85%; the middle value lies beyond the limit too.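

Among these compounds, no step among compound 1, compound 2 and compound 3 can be read in this assay, since each result is a limit and not a number: the limit of > 25000 nM in this assay, at which 3 of the 3 values shown sit. From the compounds shown here alone, how hydrogen, bromo and fluoro on this aromatic ring compare remains open.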